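Replacing phenylcarbamoyl with (4-methylphenyl)sulfonyl on the ring nitrogen

The source may report more compounds than this note shows. Statements on the series, on what has been measured and on what is new or still open speak of the compounds shown alone.

Three compounds have been measured in an assay for binding affinity to Adrenergic receptor alpha-1 (Rattus norvegicus); on this read-out higher numbers stand for weaker inhibition and lower numbers for stronger inhibition:
compound 1 `COc1cc2nc(N3CCN(/C(S)=N/c4ccccc4)CC3)nc(N)c2cc1OC` with 0.00692 nM;
compound 2 `COc1cc2nc(N3CCN(/C(S)=N/C4CCCCC4)CC3)nc(N)c2cc1OC` with 5.37 nM;
compound 3 `COc1cc2nc(N3CCN(C(=O)Nc4ccccc4)CC3)nc(N)c2cc1OC` with 27.5 nM.

Compound 3 gives the highest number of the three in this assay; the nearest step is a 5.1-fold higher number from compound 2 to compound 3 (0.71 log units; beyond the scatter), and the furthest is a 4000-fold higher number from compound 1 to compound 3 (3.60 log units; beyond the scatter). Compound 4 `COc1cc2nc(N3CCN(S(=O)(=O)c4ccc(C)cc4)CC3)nc(N)c2cc1OC` differs from compound 3 by (4-methylphenyl)sulfonyl in place of phenylcarbamoyl on an amine nitrogen in a ring. Among the compounds with values here, no measured step puts a sulfonyl on that ring nitrogen; the two steps that reach compound 3 exchange a sulfur-bearing group for the oxygen-bearing phenylcarbamoyl, and both raise the number, modestly from compound 2 and strongly from compound 1. They set no direction for the present change, so only a modest step of uncertain direction is expected, as a 1.4-fold lower number from compound 3 to compound 4 (0.14 log units; within the scatter). Compound 4 is estimated at 20 nM, within 3 nM to 150 nM.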

Compound 4, half-maximal inhibitory concentration: 11.5 nM
Compound 4: the middle estimate sits 1.7-fold (0.24 log units) above what was measured, within the range that was stated.
By their numbers in this assay, from the lowest: compound 1; then compound 2; then compound 4; then compound 3.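

In this assay, (4-methylphenyl)sulfonyl on the ring nitrogen gives a 2.4-fold lower number from compound 3 to compound 4 (0.38 log units; beyond the scatter), so a modest change accompanies the move from 1 hydrogen-bond donor in phenylcarbamoyl to 0 in the entering group. Against the two sulfur-bearing groups with a double-bonded nitrogen, the sulfonyl change gives a 2.1-fold higher number from compound 2 to compound 4 (0.33 log units; beyond the scatter) and a 1700-fold higher number from compound 1 to compound 4 (3.22 log units; beyond the scatter), so only the second of these is large. Nothing shown accounts for these steps. The compounds shown leave open whether phenylsulfonyl without the methyl, or methylsulfonyl, on that nitrogen would give a similar number.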